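A few compounds are considered here, and "the series" means these few. Any claim that something is new, unique, unknown or untested is made for them only; others in the source may bear on it.

Compound 1 `Clc1ccc(-c2nnc(-c3nsc4ccccc34)o2)cc1`: 13%
Compound 2 `COc1ccc(-c2nnc(-c3nsc4ccccc34)o2)cc1`: 21%
Compound 3 `Clc1ccc(Nc2nnc(-c3nsc4ccccc34)o2)cc1`: 14%

All three were tested in a functional assay on the whole organism for inhibition, with Rattus norvegicus as the target, with a stated time of 2 h, at a dose of 100 mg/kg by the oral route; on this read-out lower numbers stand for less inhibition and higher numbers for more inhibition at the one dose given (going by the name of the read-out). Compound 1 and compound 2 share a core and differ in one place: methoxy in place of chloro on an aromatic carbon. This change gave a number 8 percentage points higher from compound 1 to compound 2 (within the scatter). The difference between the core of compound 3 and the core of compound 1 is not broken down here; their values in this assay lie within the scatter of each other.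

Compound 4 `COc1ccc(Nc2nnc(-c3nsc4ccccc34)o2)cc1` is not yet measured. It differs from compound 3 in one place: methoxy in place of chloro on an aromatic carbon. Among the compounds with values here, the place is the same in both cases, so this is the same change as the one from compound 1 to compound 2. The step from compound 3 to compound 4 is therefore expected to be a number 8 percentage points higher from compound 3 to compound 4 (within the scatter), because the earlier step was a number 8 percentage points higher from compound 1 to compound 2 (within the scatter). Compound 4 is estimated to give 22% in this assay, with a range from 8% to 38%.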

Compound 4, a percentage reported as inhibition, in the whole organism at one dose (the size of the read-out at that dose, not a potency): 28%
For compound 4 the middle estimate is 6 percentage points below the measured one, within the range that was stated.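

Measured in this assay the swap of chloro for methoxy gave a number 14 percentage points higher from compound 3 to compound 4 (beyond the scatter) and the question is whether this matches the earlier step. The two steps point the same way and do not differ by more than the scatter allows, so on these two pairs the change carried over from one core to the other: the same change on two cores in this assay, a number 8 percentage points higher (within the scatter) from compound 1 to compound 2 and a number 14 percentage points higher (beyond the scatter) from compound 3 to compound 4, 6 percentage points apart, within the scatter of two such steps. Within the data shown here, this rests on only two pairs at a single dose, and of the two steps only the new one lies beyond the scatter, so it shows no general rule for the series and no reason for the rise.

The compounds shown leave open how other groups at this place would read, such as an amine, a carboxylic acid or a longer chain like butoxy. They also leave open whether the two cores would keep matching with such groups.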